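Swapping a furan for a cyclopropyl on the shared core

A few compounds are considered here, and "the series" means these few. Any claim that something is new, unique, unknown or untested is made for them only; others in the source may bear on it.

Of the compounds shown here, three with a shared hydrazine-urea core have been tested in a functional assay on SW620/5-FU cells (Homo sapiens) for cytotoxicity, read by MTT assay, with a stated time of 48 h, in the presence of a further agent that is not named here; on this read-out higher numbers stand for an effect only at larger amounts of compound and lower numbers for an effect already at smaller amounts. Compound 1 `Cc1c(Cc2ccccc2)c(NNC(=O)Nc2cc(Cl)nc(Cl)c2)nc2c1cnn2C` carries a benzyl group and gives 21400 nM. Compound 2 `Cc1nn(C)c2nc(NNC(=O)Nc3cc(Cl)nc(Cl)c3)cc(-c3ccc(F)cc3)c12`, which carries a 4-fluorophenyl group instead, gives 17400 nM. Compound 3 `Cc1nn(C)c2nc(NNC(=O)Nc3cc(Cl)nc(Cl)c3)cc(-c3ccco3)c12` carries a furan-2-yl group at the same place. For compound 3 this assay reports only a limit, > 100000 nM, so its true number is not known; it sits at the limit of > 100000 nM in this assay, at which 1 of the 3 values shown sits. Going by the values given here, the one step that can be read from these numbers is an at least 5.7-fold higher number from compound 2 to compound 3 (0.75 log units; beyond the scatter), so the furan-2-yl group was clearly less favourable than the 4-fluorophenyl group.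

Compound 4 `Cc1nn(C)c2nc(NNC(=O)Nc3cc(Cl)nc(Cl)c3)cc(C3CC3)c12` has not been measured yet. It differs from compound 3 in one place: cyclopropyl in place of furan-2-yl on an aromatic carbon. Among the compounds with values here, no measured step involves a cyclopropyl group, so the direction of this change cannot be read from the data; the only guide is that both compounds bearing a six-membered aromatic group at this position gave numbers far from the limit, while the furan-2-yl compound did not. Compound 4 is therefore expected to give about 60000 nM in this assay, most likely between 15000 nM and 200000 nM, which would mean an estimated step of an at least 1.6-fold lower number from compound 3 to compound 4 (0.22 log units; that floor lies within the scatter).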

Compound 4, half-maximal effective concentration: 80800 nM
The estimate for compound 4 lay 1.3-fold (0.13 log units) below the measured number; the range from low to high includes it.
By their numbers in this assay, from the lowest: compounds 2 and 1 (each within the scatter of the next); then compound 4. At a limit, above all of these: compound 3.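

In this assay, compound 4 shows that this position can carry a three-membered non-aromatic ring of carbon only and still give a real number, something the furan-2-yl group of compound 3 did not do. Going by these compounds, the change from furan-2-yl reads as an at least 1.2-fold lower number from compound 3 to compound 4 (0.09 log units; that floor lies within the scatter), so its true size stays unknown, while the change from 4-fluorophenyl reads as a 4.6-fold higher number from compound 2 to compound 4 (0.67 log units; beyond the scatter), which leaves the 4-fluorophenyl compound with the lowest number of the three that differ only here. Compound 3 remains a limit of the assay and not a number: the limit of > 100000 nM in this assay, at which 1 of the 4 values shown sits.

These compounds cannot separate what the 4-fluorophenyl group contributes through its ring from what its fluorine contributes, and a plain phenyl ring at this position would speak to that. How a pyridine ring, a morpholine ring or a simple amine would behave at this position also stays open, so the compounds shown give only a first outline of what this position tolerates.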